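Replacing difluoromethoxy with methylsulfinyl on a phenethyl chain

The source may report more compounds than this note shows. Statements on the series, on what has been measured and on what is new or still open speak of the compounds shown alone.

The set holds three measured compounds: compound 1 `Cc1ccc(C(F)F)cc1`, compound 2 `COc1ccc(C(F)F)cc1` and compound 3 `FC(F)OCCc1ccccc1`. In a physicochemical assay for lipophilicity, read by spectrophotometry, using the shake flask method, measured as octanol-water partition (a lower number here means a more polar compound, a higher number a more lipophilic compound), compound 1 gives 2.94, compound 2 gives 2.61 and compound 3 gives 3.16. Among the measured compounds shown here, the one step between compounds that differ in a single place is a number 0.33 log units lower from compound 1 to compound 2 (beyond the scatter). Compound 3 stands highest of the three numbers, though its gap to compound 1 lies within the scatter, while its gap to compound 2 lies beyond it.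

Compound 4 `C[S+]([O-])CCc1ccccc1` differs from compound 3 by a group of 3 heavy atoms (1 carbon, 1 oxygen, 1 sulfur; no ring) in place of a group of 4 heavy atoms (1 carbon, 1 oxygen, 2 fluorine; no ring), on a saturated chain carbon, two bonds along the chain from an aromatic carbon. For the measured compounds named here, no measured step matches this change: the step from compound 1 to compound 2 concerns an aromatic carbon and a different pair of groups, so it offers no direct guide. The author therefore rests the expectation on the counted change alone, and expects a large downward step, a number 2.06 log units lower from compound 3 to compound 4 (beyond the scatter), well beyond the scatter. For compound 4 in this assay the estimate is 1.1, with a range from 0.5 to 1.7.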

Compound 4, partition coefficient: 0.63
Beside the measured number, compound 4's estimate is 0.47 log units above it; the measured number falls inside the stated range.
By their numbers in this assay, from the lowest: compound 4; then compound 2; then compounds 1 and 3 (each within the scatter of the next).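

Among the compounds shown here, at this place, on a saturated chain carbon, two bonds along the chain from an aromatic carbon, the exchange of difluoromethoxy for the group of 3 heavy atoms (1 carbon, 1 oxygen, 1 sulfur) gives a number 2.53 log units lower from compound 3 to compound 4 (beyond the scatter) in this assay, far larger than the only earlier step, a number 0.33 log units lower from compound 1 to compound 2 (beyond the scatter), which concerned a different pair of groups on an aromatic carbon. The two groups have the same counts of hydrogen-bond donors and acceptors, no ring and no net charge, so those counts do not tell them apart. Nothing measured here accounts for the size of the step.

The compounds shown leave open whether the same exchange gives a step of like size on an aromatic carbon or on a longer chain. They also leave open how a methylthio group or a methylsulfonyl group would stand at this place.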